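Notes on the step from compound 3 to compound 4

A few compounds are considered here, and "the series" means these few. Any claim that something is new, unique, unknown or untested is made for them only; others in the source may bear on it.

Four compounds share a sulfonyl-linked side chain ending in a five-membered ring. Compound 1 `COc1ccc(C2=NN(c3ccccc3)C(c3ccc(C)cc3)C2S(=O)(=O)CC2=NCCS2)cc1` in a functional assay, tested at 50 ug/mL (on this read-out higher numbers stand for a stronger effect at the one concentration tested and lower numbers for a weaker effect), gives 42.6%. Compound 2 `O=S(=O)(CC1=NCCO1)C1=NNCC1c1ccccc1` in this assay is reported as "not active" (no number reported), with no number behind it. Compound 3 `COc1ccc(-c2noc(-c3ccc(C)cc3)c2S(=O)(=O)CC2=NCCS2)cc1` in this assay is likewise reported as "not active" (no number reported), again without a number, so compound 3 stands among the entries that carry no value, and compound 2 is the one further entry in that position. Within the data shown here, no pair of measured compounds differs in a single place, so no measured step is available to size such a change.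

Compound 4 `COc1ccc(-c2noc(-c3ccc(C)cc3)c2S(=O)(=O)CC2=NCCO2)cc1` is not yet measured. It differs from compound 3 in one place: a group of 5 heavy atoms (3 carbon, 1 nitrogen, 1 oxygen; one five-membered non-aromatic ring with 2 hetero atoms) in place of a group of 5 heavy atoms (3 carbon, 1 nitrogen, 1 sulfur; one five-membered non-aromatic ring with 2 hetero atoms), on a saturated chain carbon bound to a sulfonyl sulfur. Among the measured compounds shown here, the ring that enters is the one also carried by compound 2, which itself returns no number. In this assay the step from compound 3 to compound 4 is therefore expected to bring no change beyond the scatter, and a report without a number is the more likely outcome. Should a number be reported, compound 4 is estimated at about 10%, within a range from 0% to 30%.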

Compound 4, a percentage reported as activity, at one concentration (the size of the read-out at that concentration, not a potency): 70%
The estimate for compound 4 lay 60 percentage points below the measured number; measured number outside the range, above it.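

No step can be read from compound 3 to compound 4 in this assay, since compound 4 gives 70% and compound 3 carries no number. Nothing shown bears on a cause for this result. The compounds shown leave open how this ring exchange acts on the core of compound 1.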